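A few compounds are considered here, and "the series" means these few. Any claim that something is new, unique, unknown or untested is made for them only; others in the source may bear on it.

In a functional assay on BT-474 cells (Homo sapiens) for inhibition, read by fluorescence, with a stated time of 72 h (a lower number here means a stronger inhibitor of growth, a higher number a weaker inhibitor of growth), three compounds that carry the 3,5-dimethoxyphenyl group differ only in their saturated chain. Compound 1 `COc1cc(Nc2nc(N[C@H]3CC[C@H](N)CC3)nc3c2ncn3CCC(C)C)cc(OC)c1` gives 5900 nM, compound 2 `CCCCCCn1cnc2c(Nc3cc(OC)cc(OC)c3)nc(N[C@H]3CC[C@H](N)CC3)nc21` gives 3700 nM, and compound 3 `CCCCn1cnc2c(Nc3cc(OC)cc(OC)c3)nc(N[C@H]3CC[C@H](N)CC3)nc21` gives 15600 nM, the highest of the three numbers. Compound 4 `CCCCn1cnc2c(Nc3ccccc3)nc(N[C@H]3CC[C@H](N)CC3)nc21` keeps the chain of compound 3 but changes the other substituent: phenyl in place of 3,5-dimethoxyphenyl on a nitrogen on an aromatic ring. This puts phenyl in place of 3,5-dimethoxyphenyl on a nitrogen on an aromatic ring.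

Going by the values given here, no measured step touches that group. The available steps all change the chain: a 1.6-fold lower number from compound 1 to compound 2 (0.20 log units; within the scatter), a 2.6-fold higher number from compound 1 to compound 3 (0.42 log units; beyond the scatter) and a 4.2-fold higher number from compound 2 to compound 3 (0.62 log units; beyond the scatter). They therefore give only a rough guide to size, with a 4.2-fold higher number from compound 2 to compound 3 (0.62 log units; beyond the scatter) as the largest, and none to direction. A small move toward a higher number is expected, not beyond the scatter. The estimated change is a 1.3-fold higher number from compound 3 to compound 4 (0.11 log units; within the scatter). For compound 4 the estimated value is 20000 nM, with an expected range from 8000 nM to 50000 nM.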

Compound 4, concentration for 50% growth inhibition: 4900 nM
Compound 4: middle estimate off by 4.1-fold (0.61 log units), on the high side, outside the stated range (below it).
By their numbers in this assay, from the lowest: compounds 2, 4 and 1 (each within the scatter of the next); then compound 3.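

In this assay, phenyl in place of 3,5-dimethoxyphenyl on a nitrogen on an aromatic ring gives a 3.2-fold lower number from compound 3 to compound 4 (0.50 log units; beyond the scatter), a move toward stronger growth inhibition that lies beyond the scatter. The earlier compounds shown here all carried 3,5-dimethoxyphenyl and varied only in the saturated chain, so they could not show that this position also moves the number, or that, with the chain of compound 3, the two methoxy groups are not needed for this level of growth inhibition. Nothing shown accounts for the direction or size of this step.

From the compounds shown here alone, it remains open whether a single methoxy group, or an amine or a carboxylic acid on the phenyl ring, would shift the number further. Going by these compounds, it is also open whether the same change would give a similar step with the chain of compound 1 or compound 2.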